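Methyl to Methoxy: Estimating Compound 3

The source may hold more compounds than are shown below. What is called first, only, known or untested is meant among the compounds shown, and "the series" means these compounds.

Compound 1 `O=C(/C=C/C1=Cc2ccccc2OC1)c1ccc(C(F)(F)F)cc1`: 75.5%
Compound 2 `Cc1ccc(C(=O)/C=C/C2=Cc3ccccc3OC2)cc1`: 53.1%

Of the compounds shown here, two have been measured in a functional assay on the whole organism for inhibition, with Mus musculus as the target, with a stated time of 1 h, at a dose of 30 mg/kg by the intraperitoneal route; on this read-out higher numbers stand for more inhibition at the one dose given (going by the name of the read-out) and lower numbers for less inhibition. Compound 1 gives 75.5%, and compound 2 gives 53.1%. Among the compounds with values here, compound 2 therefore stands lowest of the two numbers; its nearest neighbour is compound 1, and the only measured step, a number 22.4 percentage points lower from compound 1 to compound 2 (beyond the scatter), separates them.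

Compound 3 `COc1ccc(C(=O)/C=C/C2=Cc3ccccc3OC2)cc1` has not yet been measured. It differs from compound 2 in one place: methoxy in place of methyl on an aromatic carbon.

Within the data shown here, the single measured step concerns a different swap, trifluoromethyl against methyl, and so says little about what methoxy in place of methyl will do. Its size shows that one change on this ring can move the read-out beyond the scatter, but it gives no direction for the present change. Without a closer comparison, the step from compound 2 to compound 3 is expected to be small, a number 3.1 percentage points lower from compound 2 to compound 3 (within the scatter), with a wide uncertainty on either side. Compound 3 is therefore estimated at 50%, within a range from 25% to 75%.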

Compound 3, a percentage reported as inhibition, in the whole organism at one dose (the size of the read-out at that dose, not a potency): 66.2%
Estimate against measurement, compound 3: 16.2 percentage points below; low and high end bracket the measured number.
By their numbers in this assay, from the lowest: compound 2; then compounds 3 and 1 (each within the scatter of the next).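

In this assay, methoxy in place of methyl on the aromatic carbon para to a large group gives a number 13.1 percentage points higher from compound 2 to compound 3 (beyond the scatter), which shows that a swap from methyl to a group other than trifluoromethyl can also move the read-out beyond the scatter. Methoxy and trifluoromethyl cannot be told apart at this place, with a number 9.3 percentage points lower from compound 1 to compound 3 (within the scatter), so among these three compounds methyl is the only group that stands apart, and two quite different groups can give similar numbers here. Nothing available explains why methyl differs from the other two groups.

The compounds shown leave open whether the oxygen of methoxy matters in itself or whether other groups at this place would give similar numbers; a hydroxyl, an ethoxy, a chlorine or an amine would help to separate these possibilities. From the compounds shown here alone, each number is also a reading at one dose and one time, so how these compounds compare at other doses or times remains unknown.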